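A Chloro for Fluoro Swap on the Aromatic Ring

This account rests on a few compounds, and the source may have more. Where it says the series, first, only, none or still open, it means among the compounds named here.

Compound 2, `CC1=CC[C@H](C(C)(C)NC(=S)N/N=C/c2ccc(F)cc2)CC1`, carries a 4-fluorophenyl group on the shared core. In a functional assay on 786-0 cells (Homo sapiens) for inhibition, read by sulforhodamine B assay, with a stated time of 48 h (on this read-out higher numbers stand for weaker inhibition of growth and lower numbers for stronger inhibition of growth), compound 2 reaches only the limit of the assay, > 100000 nM, so no number is known for it. Compound 1, `CC1=CC[C@H](C(C)(C)NC(=S)N/N=C/c2ccccc2)CC1`, carries the plain phenyl group instead, and in this assay compound 1 gives 67000 nM. The step from compound 1 to compound 2 is an at least 1.4-fold higher number from compound 1 to compound 2 (0.17 log units; that floor lies within the scatter), and because of the limit of > 100000 nM in this assay, at which 1 of the 2 values shown sits, the true size of that step cannot be told.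

Compound 3, `CC1=CC[C@H](C(C)(C)NC(=S)N/N=C/c2ccccc2Cl)CC1`, differs from compound 2 by 2-chlorophenyl in place of 4-fluorophenyl on a carbon with a double bond to nitrogen. For the measured compounds named here, the only measured step touching this ring is the one from compound 1 to compound 2, which has no size beyond its floor, so nothing measured points to a move in either direction in this assay. The expected step is therefore an at least 1.1-fold lower number from compound 2 to compound 3 (0.04 log units; that floor lies within the scatter), meaning compound 3 is expected to remain near the limit. For compound 3 the estimate in this assay is 90000 nM, with a range from 35000 nM to 250000 nM, and a real chance that only a limit is reported again.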

Compound 3, concentration for total growth inhibition: > 100000 nM
Compound 3: only a limit was reported (the forecaster's own chance of this, stated with the estimate: 55%); middle value at least 1.1-fold (0.04 log units) away from the limit.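

Compound 3 is the second compound on the shared core with a halogen on the aromatic ring, and in this assay compound 3 again gives only a limit, > 100000 nM, not a number. Measured against the plain phenyl group, the 2-chlorophenyl group gives an at least 1.4-fold higher number from compound 1 to compound 3 (0.17 log units; that floor lies within the scatter), so what this position now shows is that two different halogen-bearing rings, in compound 2 and compound 3, both end at a limit, while only compound 1 has a real number, and even so this floor alone does not establish a real loss of growth inhibition. The step between compound 2 and compound 3 cannot be read, so fluoro and chloro cannot be ranked here, because both compounds stand at a limit: the limit of > 100000 nM in this assay, at which 2 of the 3 values shown sit.

Still open, going by these compounds, is whether the halogen or its place on the ring matters, since compound 2 and compound 3 differ in both, and a 4-chlorophenyl group would separate the two. Also open, on these data alone, is whether any group on this ring, such as an amine or a carboxylic acid, gives a lower number than the plain phenyl group of compound 1.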